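The source may hold more compounds than are shown below. What is called first, only, known or untested is meant among the compounds shown, and "the series" means these compounds.

Measured so far:
- Compound 1, `CC(C)Cn1c(=O)n(C)c(=O)c2nc(SCCO)c(Cc3cccc4ccccc34)nc21`: 2850 nM
- Compound 2, `CC(C)Cn1c(=O)n(C)c(=O)c2nc(C(=O)NCCCO)c(Cc3cccc4ccccc34)nc21`: > 10000 nM

In a functional assay on Raji cells (Homo sapiens) for inhibition, read by MTT assay, with a stated time of 96 h (a higher number here means that more compound is needed for the effect, a lower number that less compound is needed), compound 1 gives 2850 nM, the only number shown in the series. For compound 2 the result is a limit, > 10000 nM, as marked by the limit of > 10000 nM in this assay, at which 1 of the 2 values shown sits. Going by the values given here, the one step with a number behind it, an at least 3.5-fold higher number from compound 1 to compound 2 (0.54 log units; beyond the scatter), is the sole measured guide and concerns a different replacement.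

Compound 3, `CC(C)Cn1c(=O)n(C)c(=O)c2nc(CCCCCO)c(Cc3cccc4ccccc34)nc21`, is yet to be measured. It differs from compound 1 by 5-hydroxypentyl in place of (2-hydroxyethyl)sulfanyl on an aromatic carbon. Among the compounds with values here, no measured step covers this exchange: the change from compound 1 to compound 2 swaps in a carbamoyl group, whereas compound 3 keeps an uncharged hydroxyalkyl substituent at the same position. The step from compound 1 to compound 2 only shows that this position does not tolerate every change, so the expectation for compound 3 is a step of no more than modest size, more likely towards a higher number than a lower one, with a real chance of landing at the limit.

The estimate for compound 3 is 4500 nM, within 1500 nM to 13000 nM, which is expected to correspond to a 1.6-fold higher number from compound 1 to compound 3 (0.20 log units; within the scatter).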

Compound 3, half-maximal effective concentration: 58 nM
Estimate against measurement, compound 3: 78-fold (1.89 log units) above; measured number below the stated range.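

In this assay, the position next to the ring nitrogen proves far more responsive than compound 2 alone could show: 5-hydroxypentyl in place of (2-hydroxyethyl)sulfanyl gives a 49-fold lower number from compound 1 to compound 3 (1.69 log units; beyond the scatter), so a single exchange here can move the value strongly downward. Against (3-hydroxypropyl)carbamoyl, the same chain gives an at least 170-fold lower number from compound 2 to compound 3 (2.23 log units; beyond the scatter), so these three substituents, each ending in a hydroxyl, are not interchangeable on the shared core. The value of compound 2 is a limit and not a number, so this second step sets only a lower bound on the size of the change: the limit of > 10000 nM in this assay, at which 1 of the 3 values shown sits.

The three compounds differ both in the atom joined to the core and in chain length, so the large step from the sulfanyl chain to the 5-hydroxypentyl chain cannot be assigned to either feature alone. On these data alone, it also stays open how a plain pentyl chain, a longer hydroxyalkyl chain, or a chain ending in an amine or a carboxylic acid would compare with compound 3.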